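Compound 1 to compound 4: a step from a limit

This account rests on a few compounds, and the source may have more. Where it says the series, first, only, none or still open, it means among the compounds named here.

Compound 1 `C=C[C@@](C)(/C=C/c1ccc(OS(=O)(=O)C(F)(F)F)cc1)CCC=C(C)C` is the starting point, tested in a functional assay on SEM cells (Homo sapiens) for cytotoxicity, with a stated time of 72 h; a higher number here means that more compound is needed for the effect, a lower number that less compound is needed. In this test compound 1 gives > 36600 nM, which is a limit and not a number. Compound 2 `C=C[C@@](C)(/C=C/c1ccc(OS(=O)(=O)c2ccc(C)cc2)cc1)CCC=C(C)C` gives > 43400 nM, again a limit. Compound 3 `COc1ccc(/C=C/[C@@](C)(/C=C/c2ccc(O)c(/C=C/C(=O)OCc3ccccc3)c2)CCC=C(C)C)cc1` gives > 36600 nM, also a limit. Compound 1 therefore stands at a limit, and none of the three measured compounds offers an actual number to build on.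

Compound 4 `C=C[C@@](C)(/C=C/c1ccc(Nc2ccc(Cl)c(F)c2)cc1)CCC=C(C)C` changes one group on the core of compound 1: (4-chloro-3-fluorophenyl)amino in place of ((trifluoromethyl)sulfonyl)oxy on an aromatic carbon. In words, (4-chloro-3-fluorophenyl)amino comes in place of ((trifluoromethyl)sulfonyl)oxy on an aromatic carbon, para to a large group. Among the compounds with values here, only one measured step comes near this change: a step that the two limits leave unreadable from compound 1 to compound 2, where 4-methylphenyl takes the place of trifluoromethyl on a sulfonyl sulfur. That step also brings in an aromatic ring, but with limits at both ends it gives no size to carry over, and the change to compound 4 also removes the sulfonyl group altogether.

Any expectation in this assay is therefore loose. The step expected is an at least 1.4-fold lower number from compound 1 to compound 4 (0.16 log units; that floor lies within the scatter), a modest estimated move towards less compound being needed, and the assay may again report only a limit. For compound 4 the estimated value is 25000 nM, with an expected range from 6000 nM to 60000 nM.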

Compound 4, half-maximal effective concentration: > 36600 nM
Compound 4 gave a limit, no number; the forecaster's own chance of this, stated with the estimate: 55%; middle value at least 1.4-fold (0.16 log units) from the limit.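

In this assay, compound 4 gives only a limit and no number, and so does compound 1, so the step between these two compounds cannot be read. The compounds shown leave open how much of each compound is actually needed for the effect, and so how large a difference any swap on the shared core makes.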